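This account rests on a few compounds, and the source may have more. Where it says the series, first, only, none or still open, it means among the compounds named here.

Compound 2 `CC(C)C(=O)N1CC2CC(C1)N2` gives 19000 nM in an assay on SH-EP1 cells for agonist activity at Neuronal acetylcholine receptor; alpha4/beta2 (Homo sapiens), read by FLIPR and calcium flux (on this read-out lower numbers stand for an effect already at smaller amounts and higher numbers for an effect only at larger amounts of compound), the highest of the three numbers recorded; compound 3 `O=C(CC1C=CCC1)N1CC2CC(C1)N2` at 14000 nM sits within the scatter of it, while compound 1 `CC(=O)N1CC2CC(C1)N2` at 5100 nM lies well below. Compound 4 `C[C@@H]1C[C@H]1C(=O)N1CC2CC(C1)N2` differs from compound 2 by 2-methylcyclopropyl in place of isopropyl on a carbonyl carbon. For the measured compounds named here, two steps bear on this: from compound 1 to compound 2 (a 3.7-fold higher number from compound 1 to compound 2 (0.57 log units; beyond the scatter)) and from compound 1 to compound 3 (a 2.7-fold higher number from compound 1 to compound 3 (0.44 log units; beyond the scatter)), both enlargements of the acyl group that raised the number modestly. The change to compound 4 adds one heavy atom and a small ring, so a step of a 1.1-fold higher number from compound 2 to compound 4 (0.02 log units; within the scatter) is expected, essentially within the scatter. Compound 4 is estimated at 20000 nM in this assay, range 8000 nM to 50000 nM.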

Compound 4, half-maximal effective concentration: 190 nM
Compound 4: middle estimate off by 110-fold (2.02 log units), on the high side; measured number outside the range, below it.
By their numbers in this assay, from the lowest: compound 4; then compound 1; then compounds 3 and 2 (each within the scatter of the next).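

Size alone does not set the number at the group on the carbonyl carbon: a small change in heavy atoms, with 2-methylcyclopropyl in place of isopropyl, gives a 100-fold lower number from compound 2 to compound 4 (2.00 log units; beyond the scatter). Replacing methyl with isopropyl gave a 3.7-fold higher number from compound 1 to compound 2 (0.57 log units; beyond the scatter), whereas replacing it with 2-methylcyclopropyl gives a 27-fold lower number from compound 1 to compound 4 (1.43 log units; beyond the scatter), so this position can move the number strongly in either direction. Nothing available accounts for this reversal.

On these data alone, it remains open whether the three-membered ring, its methyl or the two defined stereocentres carry the change. Plain cyclopropyl and the opposite stereoisomer of 2-methylcyclopropyl would help separate these.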